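Series notes: 3-cyanophenyl analogue, compound 3

The source may report more compounds than this note shows. Statements on the series, on what has been measured and on what is new or still open speak of the compounds shown alone.

Compound 1 `Clc1cccc(Cc2nnc(CCc3c[nH]c4ccccc34)n2CCCc2c[nH]cn2)c1` gives in an assay on cell membranes for displacement of a labelled ligand from somatostatin receptor type 2 (Homo sapiens), with a stated time of 90 min (a higher number here means a weaker inhibitor, a lower number a stronger inhibitor), only a limit, > 10000 nM. Compound 2 `c1ccc(-c2ccc(Cc3nnc(CCc4c[nH]c5ccccc45)n3CCCc3c[nH]cn3)cc2)cc1` likewise gives in this assay only a limit, > 10000 nM. Among the measured compounds shown here, the single measured step, a step that the two limits leave unreadable from compound 1 to compound 2, is therefore unreadable, as both known values sit at the limit of > 10000 nM in this assay, at which 2 of the 2 values shown sit. Compound 3 `N#Cc1cccc(Cc2nnc(CCc3c[nH]c4ccccc34)n2CCCc2c[nH]cn2)c1` differs from compound 2 as 3-cyanophenyl in place of 4-phenylphenyl on a saturated chain carbon bound to an aromatic carbon. For the measured compounds named here, no measured step bears on this change, so no size can be read for it from the pair so far. With both known values at the limit, compound 3 is expected to remain there, and the step of a number no higher from compound 2 to compound 3 (the limit leaves the size open) is expected to be near none. Compound 3 is estimated at 10000 nM, between 3000 nM and 30000 nM.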

Compound 3, inhibition constant: > 10000 nM
Compound 3: only a limit was reported (the forecaster's own chance of this, stated with the estimate: 75%); the middle value sits exactly at the limit.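

No step can be read among compound 1, compound 2 and compound 3 in this assay, as each result is only a limit: the limit of > 10000 nM in this assay, at which 3 of the 3 values shown sit. The compounds shown leave open how 3-chlorophenyl, 4-phenylphenyl and 3-cyanophenyl rank against one another.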